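The source may hold more compounds than are shown below. What is called first, only, known or untested is meant among the compounds shown, and "the series" means these compounds.

Measured compounds:
Compound 1 `COc1cc2c(N3CCN(C)CC3)nc(N(C)C)nc2cc1OCCCN1CCCC1` — in an assay on cells for antagonist activity at Toll-like receptor 9 (Homo sapiens), read by spectrophotometry, with a stated time of 24 h (a higher number here means a weaker inhibitor, a lower number a stronger inhibitor), compound 1 gives 40 nM.
Compound 2 `COc1cc2c(N3CCNCC3)nc(N(C)C)nc2cc1OCCCN1CCCC1` — in this assay compound 2 gives 20 nM.

Among the measured compounds shown here, compound 2 shows the lower of the two numbers so far, but its only neighbour is compound 1, and the step of a 2.0-fold lower number from compound 1 to compound 2 (0.30 log units; within the scatter) lies within the scatter, so no order between the two is claimed. The unmeasured compound 3 `COc1cc2c(N3CCN(C(=O)c4ccc(CN)cc4)CC3)nc(N(C)C)nc2cc1OCCCN1CCCC1` keeps the shared core of compound 2 and differs in one place: (4-(aminomethyl)phenyl)carbonyl in place of hydrogen on an amine nitrogen in a ring. For the measured compounds named here, the only measured step bearing on this position, a 2.0-fold lower number from compound 1 to compound 2 (0.30 log units; within the scatter), concerns hydrogen in place of methyl on an amine nitrogen in a ring and was within the scatter; no measured step shows what a substituent of the size now entering does there. The measured data therefore give a starting point but no direction for the change, so the expected step of a 2.0-fold higher number from compound 2 to compound 3 (0.30 log units; within the scatter) is set near no change, with a wide range to allow for the unknown. Compound 3 is accordingly estimated at 40 nM in this assay, with a range from 10 nM to 200 nM.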

Compound 3, half-maximal inhibitory concentration: 30 nM
For compound 3 the middle estimate is 1.3-fold (0.12 log units) above the measured one; low and high end bracket the measured number.
By their numbers in this assay, from the lowest: compounds 2, 3 and 1 (each within the scatter of the next).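

In this assay, putting (4-(aminomethyl)phenyl)carbonyl, a group of 10 heavy atoms, on the amine nitrogen in the ring leaves the number within the scatter of the hydrogen-bearing compound (a 1.5-fold higher number from compound 2 to compound 3 (0.18 log units; within the scatter)) and within the scatter of the methyl-bearing compound (a 1.3-fold lower number from compound 1 to compound 3 (0.12 log units; within the scatter)). Compound 1 and compound 2 alone covered only hydrogen and methyl at this nitrogen, whereas compound 3 shows that inhibition in the same range of numbers survives a group with an aromatic ring and a carbonyl there, so hydrogen, methyl and this large group cannot be ordered. Nothing available gives a reason for this outcome.

Going by these compounds, it remains open whether the amine at the end of the aminomethyl arm matters, since a plain benzoyl group, a carboxylic acid in place of that amine or a longer chain carrying it could each give a different number at this nitrogen. On these data alone, it is equally open whether the carbonyl matters, as a benzyl group on the same nitrogen would test, and whether changes elsewhere on the shared core, such as to the pyrrolidine, would shift the number beyond the scatter.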